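Ester for morpholine amide on the alkyne series

A few compounds are considered here, and "the series" means these few. Any claim that something is new, unique, unknown or untested is made for them only; others in the source may bear on it.

Compound 1, `O=C(c1cccc(C#Cc2ccccc2Nc2ncnc3ccc(Cl)nc23)c1)N1CCOCC1`, carries an alkyne-linked aryl bearing a (morpholin-4-yl)carbonyl group on the shared core. In an assay on isolated protein for inhibition of MAP kinase-interacting serine/threonine-protein kinase 2 (Homo sapiens), read by HTRF, in the presence of a further agent that is not named here (a higher number here means a weaker inhibitor, a lower number a stronger inhibitor), compound 1 gives only a limit, > 10000 nM; it is one of the values described by the limit of > 10000 nM in this assay, at which 1 of the 3 values shown sits, so no number is known for it. Two further members of the core are measured. Compound 2, `N#Cc1ccc(Nc2ncnc3ccc(-c4ccc(C(=O)N5CCNCC5)cc4)nc23)cc1`, in this assay gives 43 nM. Compound 3, `COC(=O)c1oc2ccc(Nc3ncnc4ccc(Cl)nc34)cc2c1C`, which already carries a methoxycarbonyl group on a fused ring attached through an amine, in this assay gives 4800 nM.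

Compound 4, `COC(=O)c1cccc(C#Cc2ccccc2Nc2ncnc3ccc(Cl)nc23)c1`, has not been measured. It differs from compound 1 in one place: methoxy in place of morpholin-4-yl on a carbonyl carbon, leaving the alkyne linker and the core untouched. Going by the values given here, no measured pair shows this same change, so its size is open. Because compound 1 sits at > 10000 nM, only a limit, the step can only be read from the estimate for compound 4 itself. The expectation is that the step from compound 1 to compound 4 stays within the scatter, a step that the limit leaves unreadable from compound 1 to compound 4, with the methyl ester of compound 3 at 4800 nM marking roughly where a weak ester on this core can land. Compound 4 is therefore estimated at 12000 nM, within 3000 nM to 40000 nM, and a further limit rather than a number would not be surprising.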

Compound 4, half-maximal inhibitory concentration: 4200 nM
The estimate for compound 4 lay 2.9-fold (0.46 log units) above the measured number; low and high end bracket the measured number.
By their numbers in this assay, from the lowest: compound 2; then compounds 4 and 3 (each within the scatter of the next). At a limit, above all of these: compound 1.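

Exchanging morpholin-4-yl for methoxy on a carbonyl carbon, with the alkyne linker and the shared core unchanged, gives an at least 2.3-fold lower number from compound 1 to compound 4 (0.37 log units; beyond the scatter) in this assay. Going by these compounds alone, this is the first direct reading at this position, and it shows that the morpholin-4-yl ring is not needed for a measurable number on the alkyne series: compound 4 gives 4200 nM. Compound 1 stands at a limit, so the step is a floor and its true size remains unknown: the limit of > 10000 nM in this assay, at which 1 of the 4 values shown sits.

This single pair cannot separate the loss of the ring from the reduction in group size, and it cannot show whether the exchange would hold elsewhere on the shared core. Also open, going by these compounds, is how the number would respond to other groups on the same carbonyl carbon, such as a carboxylic acid, a primary amide, or the longer chain of an ethyl ester.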